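Ethoxy for Cyclopropyl on a Thiophene Acid Side Chain

The source may report more compounds than this note shows. Statements on the series, on what has been measured and on what is new or still open speak of the compounds shown alone.

Two compounds share a biaryl core linked through an oxygen-bearing chain to a five-membered sulfur ring that carries a carboxylic acid arm. Compound 1 is `Cc1cccc(C)c1-c1cccc(OCc2ccc(CCC(=O)O)s2)c1` and compound 2 is `Cc1cccc(C)c1-c1cccc(COc2ccc(C(CC(=O)O)C3CC3)s2)c1`. In a functional assay on cells for agonist activity at Free fatty acid receptor 1 (Homo sapiens), read by calcium flux (on this read-out lower numbers stand for an effect already at smaller amounts and higher numbers for an effect only at larger amounts of compound), compound 1 gives 2420 nM, and compound 2 gives 3920 nM. Compound 2 holds the higher of the two numbers, yet its gap to compound 1 lies within the usual scatter, so the two read as alike. Compound 3, `CCO[C@@H](CC(=O)O)c1ccc(OCc2cccc(-c3c(C)cccc3C)c2)s1`, has not been measured. It differs from compound 2 by 2-carboxy-1-ethoxyethyl in place of 2-carboxy-1-cyclopropylethyl on an aromatic carbon. Within the data shown here, no measured pair here tracks this change, so its effect is uncertain. Compound 3 is expected to land at 1500 nM, within 400 nM to 6000 nM. That expectation means a step of a 2.6-fold lower number from compound 2 to compound 3 (0.42 log units; beyond the scatter), a modest move toward smaller amounts that may only just clear the scatter.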

Compound 3, half-maximal effective concentration: 40100 nM
For compound 3 the middle estimate is 27-fold (1.43 log units) below the measured one, outside the stated range (above it).
By their numbers in this assay, from the lowest: compounds 1 and 2 (each within the scatter of the next); then compound 3.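

The two earlier compounds differ in more than one place, so they said nothing about this position alone. Here, a single change on the aromatic carbon next to the ring sulfur matters in this assay: 2-carboxy-1-ethoxyethyl in place of 2-carboxy-1-cyclopropylethyl gives a 10-fold higher number from compound 2 to compound 3 (1.01 log units; beyond the scatter), so this effect needs clearly larger amounts of compound 3. The change removes a three-membered carbon ring, adds an ether oxygen and brings a defined stereocentre, and no measurement shown explains the step.

Which of these parts drives the step remains open, since all of them change together in this one pair. Also open, as far as these compounds go, is whether a methoxy, a propoxy or a cyclobutyl group here, or the mirror-image form of compound 3, would give a number closer to that of compound 2.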